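Triazolyl to thiophenylmethyl at the amine nitrogen

The compounds below may be only part of what the source reports. "The series", "measured", "known", "first", "only" and "open" are said of these compounds alone.

Compound 2 `COc1cc(CNc2nc[nH]n2)ccc1OCc1ccc(Cl)nc1` gives the highest of the three numbers measured in a functional assay on HeLa cells (Homo sapiens) for inhibition, with a stated time of 72 h (a higher number here means that more compound is needed for the effect, a lower number that less compound is needed), at 69000 nM. For the measured compounds named here, compound 1 `COc1cc(CNCc2ccncc2)ccc1OCc1ccc(Cl)cc1` gives 890 nM and compound 3 `COc1cc(CNCc2ccncc2)ccc1OCc1ccc(Cl)c(Cl)c1` gives 4000 nM; the only single-point step measured, a 4.5-fold higher number from compound 1 to compound 3 (0.65 log units; beyond the scatter), does not touch the amine nitrogen and so bears little on the change at hand. Compound 4 `COc1cc(CNCc2cccs2)ccc1OCc1ccc(Cl)nc1` differs from compound 2 as follows: (thiophen-2-yl)methyl in place of 1H-1,2,4-triazol-3-yl on an amine nitrogen. Compounds 1 and 3 carry on the amine nitrogen a grouping of the same kind as the (thiophen-2-yl)methyl entering compound 4, and both give far lower numbers than compound 2, though they also differ from compound 2 elsewhere. A large drop is therefore expected, a 23-fold lower number from compound 2 to compound 4 (1.36 log units; beyond the scatter), with compound 4 estimated at 3000 nM (range 500 nM to 20000 nM).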

Compound 4, half-maximal effective concentration: 96000 nM
Compound 4: middle estimate off by 32-fold (1.51 log units), on the low side; measured number outside the range, above it.
By their numbers in this assay, from the lowest: compound 1; then compound 3; then compounds 2 and 4 (each within the scatter of the next).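

Exchanging the group on the amine nitrogen gives a 1.4-fold higher number from compound 2 to compound 4 (0.14 log units; within the scatter) in this assay on the core shared by these two compounds. At this position, 1H-1,2,4-triazol-3-yl and (thiophen-2-yl)methyl therefore cannot be told apart, and (thiophen-2-yl)methyl alone does not move the number on this core. No measured data explain this result.

From the compounds shown here alone, whether an amine or a carboxylic acid on the ring carried by this nitrogen would shift the number remains open. So does whether the same exchange would behave alike on the core of compound 1.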